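The source may hold more compounds than are shown below. What is called first, only, known or untested is meant among the compounds shown, and "the series" means these compounds.

Working notes on a small series tested in a functional assay on HOP-92 cells (Homo sapiens) for cytotoxicity, read by sulforhodamine B assay, with a stated time of 48 h; a lower number here means a stronger inhibitor of growth, a higher number a weaker inhibitor of growth. Compound 1 `ClCc1cccc(Cn2cnc3c(Cl)nc(Cl)nc32)c1` gives 3630 nM in this assay; of the two numbers recorded, this is the larger, but the gap to compound 2 is within the usual scatter, so no difference between them is claimed. Compound 2 `ClCc1cccc(Cn2cnc3nc(Cl)nc(Cl)c32)c1` gives 2750 nM in this assay. Compound 3 `ClCc1ccc(Cn2cnc3c(Cl)nc(Cl)nc32)cc1` stands in this assay as "not determined" (no result reported), so no number is available for it. Compound 4 `Nc1nc(Cl)c2ncn(Cc3cccc(CCl)c3)c2n1` is not yet measured and differs from compound 1 in one place: amino in place of chloro on an aromatic carbon. Going by the values given here, no step between measured compounds bears on this change, so the expectation rests on compound 1 alone. The step of a 1.4-fold higher number from compound 1 to compound 4 (0.14 log units; within the scatter) is expected to be modest, toward a weaker inhibitor of growth or nothing beyond the scatter. Compound 4 is estimated at 5000 nM, within the range 1500 nM to 16000 nM.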

Compound 4, concentration for total growth inhibition: 38000 nM
Estimate against measurement, compound 4: 7.6-fold (0.88 log units) below; the whole stated range lies below it.
By their numbers in this assay, from the lowest: compounds 2 and 1 (each within the scatter of the next); then compound 4.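

Amino in place of chloro on this aromatic carbon, between two ring nitrogen atoms, gives the first step in the series beyond the scatter: in this assay the change is a 10-fold higher number from compound 1 to compound 4 (1.02 log units; beyond the scatter), toward a weaker inhibitor of growth. This pair shows that the position is not indifferent to the group it carries, though it is a single pair. Nothing available accounts for this loss.

From the compounds shown here alone, whether a methylamino or methoxy group on the same carbon would behave like amino remains open. So does the effect of the same change at the remaining chloro group.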